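The source may hold more compounds than are shown below. What is called first, only, known or untested is meant among the compounds shown, and "the series" means these compounds.

Compound 1, `O=S(=O)(Nc1ccc2oc(-c3ccc(NS(=O)(=O)c4cccc5nonc45)cc3)nc2c1)c1ccc(Cl)s1`: in an assay on cells for inhibition of HSP60/HSP10 (Homo sapiens), with a stated time of 60 min (on this read-out higher numbers stand for weaker inhibition and lower numbers for stronger inhibition), compound 1 gives 13000 nM.
Compound 2, `Cc1ccc(S(=O)(=O)Nc2ccc(-c3nc4ccccc4o3)cc2)cc1`: in this assay compound 2 gives only a limit, > 100000 nM.
Compound 3, `C=Cc1ccc(S(=O)(=O)Nc2ccc3oc(-c4ccccc4)nc3c2)cc1`: in this assay compound 3 gives only a limit, > 100000 nM.

Compound 2 therefore has no number of its own in this assay; it sits at the limit of > 100000 nM in this assay, at which 2 of the 3 values shown sit, the point past which the assay reports nothing more. Compound 1 is the only one of the three with a real value, and compound 3 shares the limit with compound 2, so no ordering among these three can be drawn beyond that one number.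

Compound 4, `O=S(=O)(Nc1ccc(-c2nc3ccccc3o2)cc1)c1cccc(Cl)c1`, has not yet been measured. It differs from compound 2 in a single place: 3-chlorophenyl in place of 4-methylphenyl on a sulfonyl sulfur. Every other part of the molecule is kept. For the measured compounds named here, no measured pair in this set changes only that group, so there is no step to lean on. The expectation is that such a swap on the sulfonyl sulfur leaves the read-out where compound 2 sits, with no shift beyond the scatter, and most likely again only a limit.

Compound 4 is expected to give about 100000 nM, within a range of 30000 nM to 300000 nM. The expected step is a number no higher from compound 2 to compound 4 (the limit leaves the size open), that is, essentially none.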

Compound 4, half-maximal inhibitory concentration: 54000 nM
Compound 4: middle estimate off by 1.9-fold (0.27 log units), on the high side, and the stated range covers the measured number.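

For the compounds shown here, the sulfonyl sulfur is the first place in this set where a change in one place can be read: on this assay, 3-chlorophenyl in place of 4-methylphenyl gives an at least 1.8-fold lower number from compound 2 to compound 4 (0.26 log units; that floor lies within the scatter), a small floor rather than a full measure of the change. Compound 4 gives 54000 nM as a real number, which shows that a compound of this kind can register on the read-out and that a group on the sulfonyl sulfur can be compared there with actual numbers. Compound 2 has only a limit, so the true size of the step could be larger than its floor, and how much larger cannot be told: the limit of > 100000 nM in this assay, at which 2 of the 4 values shown sit.

These compounds leave open whether the chlorine, its place on the ring or the loss of the methyl accounts for the step, since only one swap at this spot is shown. Going by these compounds, it also remains open how the read-out would respond to a group of another kind on the sulfonyl sulfur, such as a ring carrying an amine or a carboxylic acid in place of the 3-chlorophenyl.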